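Changing the aryl group on the aromatic nitrogen

The compounds below may be only part of what the source reports. "The series", "measured", "known", "first", "only" and "open" are said of these compounds alone.

Compound 1 `N#CC1=C(N)Oc2c(N)cc3nc4ccccc4nc3c2C12C(=O)N(Cc1cnnn1-c1cccc(C(F)(F)F)c1)c1ccccc12` and compound 2 `N#CC1=C(N)Oc2c(N)cc3nc4ccccc4nc3c2C12C(=O)N(Cc1cnnn1-c1cc(Cl)ccc1Cl)c1ccccc12` share one core and differ only in the aryl group on an aromatic nitrogen. In an ADME assay on L02 cells (Homo sapiens) for antiproliferative activity, read by MTT assay, with a stated time of 48 h (on this read-out higher numbers stand for weaker inhibition and lower numbers for stronger inhibition), compound 1 gives 38100 nM. In this assay compound 2 reaches only the assay limit of > 50000 nM. That is an at least 1.3-fold higher number from compound 1 to compound 2 (0.11 log units; that floor lies within the scatter), tied to the limit of > 50000 nM in this assay, at which 1 of the 2 values shown sits. Compound 3 `N#CC1=C(N)Oc2c(N)cc3nc4ccccc4nc3c2C12C(=O)N(Cc1cnnn1-c1ccc([N+](=O)[O-])cc1[N+](=O)[O-])c1ccccc12` carries 2,4-dinitrophenyl in place of 2,5-dichlorophenyl on an aromatic nitrogen. Within the data shown here, only that one step bears on this change, and it lies within the scatter, so no shift beyond the scatter is expected. Compound 3 is expected at 50000 nM, between 25000 nM and 100000 nM. That estimate means a number no higher from compound 2 to compound 3 (the limit leaves the size open).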

Compound 3, half-maximal inhibitory concentration: 22800 nM
Compound 3: middle estimate off by 2.2-fold (0.34 log units), on the high side; measured number outside the range, below it.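

In this assay, this position can move the number beyond the scatter: 2,4-dinitrophenyl in place of 2,5-dichlorophenyl gives an at least 2.1-fold lower number from compound 2 to compound 3 (0.34 log units; beyond the scatter). Against 3-(trifluoromethyl)phenyl, the same group gives a 1.7-fold lower number from compound 1 to compound 3 (0.22 log units; within the scatter), so no difference can be claimed for that pair. From the compounds shown here alone, the full size of the first step stays open because compound 2 stands only at a limit: the limit of > 50000 nM in this assay, at which 1 of the 3 values shown sits. The compounds shown leave open how an amine on the phenyl ring would read, and whether a plain alkyl chain could take the place of the aryl group.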